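The source may hold more compounds than are shown below. What is called first, only, known or untested is meant among the compounds shown, and "the series" means these compounds.

Compound 1 `CCCCCCOc1ccc2c(=O)c(-c3ccc(O)cc3)coc2c1` gives 1500 nM in an assay (Cricetulus griseus) for inhibition of aldehyde dehydrogenase, mitochondrial (Homo sapiens); a lower number here means a stronger inhibitor, a higher number a weaker inhibitor. Compound 2 `CCOC(=O)COc1ccc2c(=O)c(-c3ccc(O)cc3)coc2c1` gives 130 nM in this assay, the lowest of the two numbers, reached through the step of a 12-fold lower number from compound 1 to compound 2 (1.06 log units; beyond the scatter). Compound 3 `O=c1c(-c2ccc(O)cc2)coc2cc(OCCCCCCCCCO)ccc12` differs from compound 2 in one place: 8-hydroxyoctyl in place of ethoxycarbonyl on a saturated chain carbon bound to an oxygen on an aromatic ring. Among the measured compounds shown here, only that single measured step bears on this change, and it runs in reverse: there a plain chain gave way to the ethoxycarbonyl that now leaves, while the entering chain is longer than the one in compound 1 and ends in a hydroxyl. The expected step is a 4.6-fold higher number from compound 2 to compound 3 (0.66 log units; beyond the scatter), partly undoing the earlier drop. Compound 3 is estimated at 600 nM, with a range from 200 nM to 2500 nM.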

Compound 3, half-maximal inhibitory concentration: 700 nM
Compound 3: the middle estimate sits 1.2-fold (0.07 log units) below what was measured; measured number inside the range.
By their numbers in this assay, from the lowest: compound 2; then compound 3; then compound 1.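

In this assay, the chain ending in a hydroxyl does not match the ethoxycarbonyl, with a 5.4-fold higher number from compound 2 to compound 3 (0.73 log units; beyond the scatter). It still improves on the plain chain, with a 2.1-fold lower number from compound 1 to compound 3 (0.33 log units; beyond the scatter), so a chain at this place can lower the number, though less than the ester-bearing group does. Nothing given here explains either step.

The compounds shown do not separate the effect of chain length from that of the terminal hydroxyl. Also open, from the compounds shown here alone, is how a carboxylic acid in place of the ethoxycarbonyl, or an amine at the chain end, would compare.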